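The compounds below may be only part of what the source reports. "The series", "measured", "known", "first", "only" and "open" are said of these compounds alone.

Compound 1 `O=C1N=C(N2N=C(c3ccccc3)CC2c2ccccc2O)S/C1=C1/C(=O)Nc2ccc(Br)cc21` gives 460 nM in a functional assay on cells (Cancer cell lines, Homo sapiens) for cytotoxicity, read by sulforhodamine B assay, with a stated time of 48 h (a lower number here means a stronger inhibitor of growth, a higher number a weaker inhibitor of growth), and compound 2 `COc1ccc(C2CC(c3ccccc3)=NN2C2=NC(=O)/C(=C3\C(=O)Nc4ccc(Br)cc43)S2)cc1` gives 390 nM; the change a 1.2-fold lower number from compound 1 to compound 2 (0.07 log units; within the scatter). Compound 3 `CN(C)c1ccc(C2CC(c3ccccc3)=NN2C2=NC(=O)/C(=C3\C(=O)Nc4ccccc43)S2)cc1` lacks the bromo that compounds 1 and 2 carry and bears a dimethylaminophenyl group. In this assay compound 3 gives 35300 nM, the highest of the three numbers, far beyond the scatter above both compound 1 and compound 2.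

Compound 4 `CN(C)c1ccc(C2CC(c3ccccc3)=NN2C2=NC(=O)/C(=C3\C(=O)Nc4ccc(Br)cc43)S2)cc1` differs from compound 3 by bromo in place of hydrogen on an aromatic carbon, on an aromatic carbon of a six-membered aromatic ring of carbon only, part of a fused or bridged system of two rings. Going by the values given here, no measured pair isolates this bromo-for-hydrogen exchange: the only single-point step, from compound 1 to compound 2, concerns the group on the saturated ring carbon, and the gap between compound 3 and compounds 1 and 2 mixes two changes. The bromo is shared by the two stronger compounds, so for compound 4 the expected step is a 5.9-fold lower number from compound 3 to compound 4 (0.77 log units; beyond the scatter), though its size is uncertain. Compound 4 is therefore estimated at 6000 nM, within 800 nM to 35000 nM.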

Compound 4, concentration for total growth inhibition: 420 nM
The estimate for compound 4 lay 14-fold (1.15 log units) above the measured number, outside the stated range (below it).
By their numbers in this assay, from the lowest: compounds 2, 4 and 1 (each within the scatter of the next); then compound 3.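

Going by these compounds alone, the step of an 84-fold lower number from compound 3 to compound 4 (1.92 log units; beyond the scatter) in this assay is the first to isolate bromo in place of hydrogen on an aromatic carbon, and it is large. With the bromo present, the group on the saturated ring carbon makes no visible difference: dimethylamino in place of methoxy gives a 1.1-fold higher number from compound 2 to compound 4 (0.03 log units; within the scatter), and 4-(dimethylamino)phenyl in place of 2-hydroxyphenyl gives a 1.1-fold lower number from compound 1 to compound 4 (0.04 log units; within the scatter), so the high number of compound 3 does not go with the dimethylaminophenyl group alone. Nothing measured here accounts for the size of the bromo step.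

The compounds shown leave open whether chloro, fluoro or a methyl group on that aromatic carbon would match the bromo. Within the data shown here, the only bromo-for-hydrogen pair carries 4-(dimethylamino)phenyl, so whether the step holds with 2-hydroxyphenyl or 4-methoxyphenyl also remains open.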